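Removing One Carbon at Two Places on Related Cores

This account rests on a few compounds, and the source may have more. Where it says the series, first, only, none or still open, it means among the compounds named here.

Compound 1, `CCCCc1c(OC)nc2nc(C(=O)c3ccccc3)cn2c1CC`: 10 mg/kg
Compound 2, `CCCCc1c(OC)nc2nc(C(=O)c3ccccc3)cn2c1C`: 2 mg/kg
Compound 3, `CCCCc1cc(OC)nc2nc(C(=O)c3ccccc3)cn12`: 10 mg/kg

In a functional assay on the whole organism with Rattus norvegicus as the target (on this read-out lower numbers stand for an effect already at smaller amounts and higher numbers for an effect only at larger amounts of compound), the change hydrogen in place of methyl on a saturated chain carbon bound to an aromatic carbon brought a 5.0-fold lower number from compound 1 to compound 2 (0.70 log units; beyond the scatter). Compound 3 carries a different core; the difference between the cores of compound 1 and compound 3 is not broken down here. The value of compound 3 sits level with that of compound 1, within the scatter, and is higher than that of compound 2.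

Compound 4, `CCCc1cc(OC)nc2nc(C(=O)c3ccccc3)cn12`, awaits measurement in this assay. It differs from compound 3 by hydrogen in place of methyl on a saturated chain carbon, three bonds along the chain from an aromatic carbon. This is the same kind of change as that from compound 1 to compound 2, not the same: there the methyl left a saturated chain carbon bound to an aromatic carbon, here it leaves a saturated chain carbon three bonds along the chain from an aromatic carbon. Because the earlier step of a 5.0-fold lower number from compound 1 to compound 2 (0.70 log units; beyond the scatter) sat at a different place, only a smaller step is expected, a 1.7-fold lower number from compound 3 to compound 4 (0.22 log units; within the scatter). Compound 4 is therefore estimated at 6 mg/kg, between 2 mg/kg and 20 mg/kg.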

Compound 4, minimum effective dose: 1 mg/kg
For compound 4 the middle estimate is 6.0-fold (0.78 log units) above the measured one, outside the stated range (below it).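

In this assay, the change from butyl to propyl gave a 10-fold lower number from compound 3 to compound 4 (1.00 log units; beyond the scatter). This step runs in the same direction as the earlier one, and the two do not differ in size beyond the scatter: the same change on two cores in this assay, a 5.0-fold lower number (0.70 log units; beyond the scatter) from compound 1 to compound 2 and a 10-fold lower number (1.00 log units; beyond the scatter) from compound 3 to compound 4, 2.0-fold (0.30 log units) apart, within the scatter of two such steps Removing one carbon thus lowered the number on both cores, but this rests on two pairs with the methyl leaving a different place in each, and it does not show that the change would carry over to other cores or places.

The compounds shown leave open how the same change would read at each place on the other core. They also leave open what a longer chain such as pentyl, or an amine, would do in place of the propyl of compound 4.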